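Replacing the 1H-indol-4-yl Group

The source may hold more compounds than are shown below. What is called first, only, known or untested is meant among the compounds shown, and "the series" means these compounds.

In a functional assay on K562 cells (Homo sapiens) for inhibition, read by trypan blue exclusion, with a stated time of 72 h (on this read-out higher numbers stand for weaker inhibition and lower numbers for stronger inhibition), compound 1 `Cn1c(=O)c(S(=O)(=O)c2ccc(Cl)cc2)cc2cnc(Nc3ccc4[nH]ccc4c3)nc21` gives 100 nM, compound 2 `Cc1ccc(S(=O)(=O)c2cc3cnc(Nc4cnc5[nH]ccc5c4)nc3n(C)c2=O)cc1` gives 15000 nM and compound 3 `Cn1c(=O)c(S(=O)(=O)c2ccc(Cl)cc2)cc2cnc(Nc3cccc4[nH]ccc34)nc21` gives 5000 nM. Compound 3 thus holds the second highest of these three numbers. For the measured compounds named here, the one measured step, a 50-fold higher number from compound 1 to compound 3 (1.70 log units; beyond the scatter), comes with 1H-indol-4-yl in place of 1H-indol-5-yl on a nitrogen on an aromatic ring, and it shows that a change at this place can be large. Compound 4 `Cn1c(=O)c(S(=O)(=O)c2ccc(Cl)cc2)cc2cnc(Nc3cnc4[nH]ccc4c3)nc21` differs from compound 3 at the same place: a group of 9 heavy atoms (7 carbon, 2 nitrogen; one five-membered aromatic ring with 1 hetero atom, one six-membered aromatic ring with 1 hetero atom) in place of a group of 9 heavy atoms (8 carbon, 1 nitrogen; one five-membered aromatic ring with 1 hetero atom, one six-membered aromatic ring of carbon only), on a nitrogen on an aromatic ring. Going by the values given here, no measured step covers this replacement directly. The closest guide is compound 2, which already carries the entering group, although it has a methyl where compound 4 has a chlorine. With compound 2 at 15000 nM, a modest step towards a higher number is expected, probably not beyond the scatter. The expected change is a 1.6-fold higher number from compound 3 to compound 4 (0.20 log units; within the scatter). For compound 4 the estimated value is 8000 nM, with an expected range of 2000 nM to 25000 nM.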

Compound 4, half-maximal inhibitory concentration: 5000 nM
Compound 4: middle estimate off by 1.6-fold (0.20 log units), on the high side, within the range that was stated.
By their numbers in this assay, from the lowest: compound 1; then compounds 3 and 4 (each within the scatter of the next); then compound 2.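

In this assay, the group with a hetero atom in its six-membered aromatic ring gives no change at the digits printed from compound 3 to compound 4 (within the scatter) when it replaces 1H-indol-4-yl, so at this place the two groups cannot be told apart. The same group also stands far from 1H-indol-5-yl, with a 50-fold higher number from compound 1 to compound 4 (1.70 log units; beyond the scatter) on that replacement, which shows that a second group at this place shares the weak reading of compound 3. Elsewhere on the scaffold, chloro in place of methyl on an aromatic carbon goes with a 3.0-fold lower number from compound 2 to compound 4 (0.48 log units; beyond the scatter) as a modest step, and no measurement offered here explains any of these steps. The compounds shown leave open how a simple phenyl or a 4-aminophenyl group on this nitrogen would read against compound 1 and compound 4. They also leave open how a methoxy group would read in place of the chloro.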